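Replacing diethylamino in compound 3

A few compounds are considered here, and "the series" means these few. Any claim that something is new, unique, unknown or untested is made for them only; others in the source may bear on it.

compound 1 `CC1=NN(C(=O)COc2ccc(Cl)cc2)C(c2ccccc2O)C1` gives "not active" (no number reported)
compound 2 `CCN(CC)CC(=O)N1N=C(C)CC1c1ccccc1O` gives 51600 nM
compound 3 `CCN(CC)CC(=O)N1N=C(C)CC1c1ccccc1OC(C)=O` gives 33200 nM

In a functional assay on HepG2 cells (Homo sapiens) for cytotoxicity, read by MTT assay, with a stated time of 48 h (on this read-out higher numbers stand for weaker inhibition and lower numbers for stronger inhibition), compound 3 lies within the scatter of compound 2, and compound 1 has no number. The next compound, compound 4 `CC(=O)Oc1ccccc1C1CC(C)=NN1C(=O)CN1CCC(C(C)=O)CC1`, differs from compound 3 as follows: 4-acetylpiperidin-1-yl in place of diethylamino on a saturated chain carbon bound to a carbonyl carbon. It keeps the acetyl on the oxygen.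

Within the data shown here, only one measured step exists, a 1.6-fold lower number from compound 2 to compound 3 (0.19 log units; within the scatter), and it concerns the acetyl in place of hydrogen, not the group now exchanged. Among the measured compounds shown here, no measured step covers a change at the saturated chain carbon. For the measured compounds named here, the sole hint is compound 1, which carries no diethylamino and gives "not active" (no number reported), although it also differs from compound 3 at the oxygen. No direction can therefore be argued from the data, and no shift beyond the scatter is assumed, though the uncertainty is wide. The estimated change is a 1.1-fold lower number from compound 3 to compound 4 (0.04 log units; within the scatter). For compound 4 the expected value is 30000 nM, within an estimated range of 10000 nM to 85000 nM.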

Compound 4, half-maximal inhibitory concentration: 7800 nM
Compound 4: middle estimate off by 3.8-fold (0.59 log units), on the high side; measured number outside the range, below it.
By their numbers in this assay, from the lowest: compound 4; then compounds 3 and 2 (each within the scatter of the next).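

In this assay, the saturated chain carbon bound to a carbonyl carbon responds to the exchange of its amine: 4-acetylpiperidin-1-yl in place of diethylamino gives a 4.3-fold lower number from compound 3 to compound 4 (0.63 log units; beyond the scatter). Among these compounds, the earlier step, a 1.6-fold lower number from compound 2 to compound 3 (0.19 log units; within the scatter), stayed within the scatter, so this is the only change so far that moves the number beyond it. No measurement on hand accounts for this step.

The compounds shown leave open whether the step follows the ring or its acetyl, a question that piperidin-1-yl without the acetyl would address, and whether morpholin-4-yl would give a similar number. Also open, as far as these compounds go, is whether 4-acetylpiperidin-1-yl gives the same step with hydrogen on the oxygen, as in compound 2, as it appears here only with the acetyl there.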